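Swapping the heteroaryl group on the thioether sulfur

The compounds below may be only part of what the source reports. "The series", "measured", "known", "first", "only" and "open" are said of these compounds alone.

Of the compounds shown here, two sharing one core have been measured in a functional assay on HT-29 cells (Homo sapiens) for cytotoxicity, read by MTT assay, with a stated time of 24 h; on this read-out higher numbers stand for weaker inhibition and lower numbers for stronger inhibition. Compound 1 `Cn1c(-c2ccc(NC(=O)CSc3nc4cc(Cl)ccc4o3)cc2)nc(-c2ccccc2)c1-c1ccccc1` gives 20.6 ug/mL. Compound 2 `Cc1nnc(SCC(=O)Nc2ccc(-c3nc(-c4ccccc4)c(-c4ccccc4)n3C)cc2)s1` gives 2.7 ug/mL, the lowest of the two numbers. For the measured compounds named here, the single change between them, a 7.6-fold lower number from compound 1 to compound 2 (0.88 log units; beyond the scatter), shows that exchanging the group on the sulfur can shift the result well beyond the scatter. Compound 3 `Cn1c(-c2ccc(NC(=O)CSC3=NCCS3)cc2)nc(-c2ccccc2)c1-c1ccccc1` differs from compound 2 by a group of 5 heavy atoms (3 carbon, 1 nitrogen, 1 sulfur; one five-membered non-aromatic ring with 2 hetero atoms) in place of a group of 6 heavy atoms (3 carbon, 2 nitrogen, 1 sulfur; one five-membered aromatic ring with 3 hetero atoms), on a sulfur. Going by the values given here, no measured step involves this new ring, so the only guide is that replacing 5-chloro-1,3-benzoxazol-2-yl by 5-methyl-1,3,4-thiadiazol-2-yl gave a much lower number. Because a 7.6-fold lower number from compound 1 to compound 2 (0.88 log units; beyond the scatter) was large, a sizeable move for compound 3 in this assay is plausible, and its direction is uncertain. For compound 3 a modest rise is expected, a 2.2-fold higher number from compound 2 to compound 3 (0.35 log units; beyond the scatter). Compound 3 is therefore estimated to give about 6 ug/mL, with a range from 1.5 ug/mL to 25 ug/mL.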

Compound 3, half-maximal inhibitory concentration: 21 ug/mL
For compound 3 the middle estimate is 3.5-fold (0.54 log units) below the measured one; the measured number falls inside the stated range.
By their numbers in this assay, from the lowest: compound 2; then compounds 1 and 3 (each within the scatter of the next).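

Replacing the 5-methyl-1,3,4-thiadiazol-2-yl group on the sulfur with the five-membered non-aromatic ring takes away the low number seen for compound 2 (a 7.8-fold higher number from compound 2 to compound 3 (0.89 log units; beyond the scatter)), so a small five-membered ring at this position is not enough to keep it. Compound 1 and compound 3 give matching numbers (a 1.0-fold higher number from compound 1 to compound 3 (0.01 log units; within the scatter)) even though the group in compound 1 carries more heavy atoms than the 5 heavy atoms of the group in compound 3, so across these three compounds the number does not follow the size of the group, and compound 2, with 6 heavy atoms, stands alone. No measurement here accounts for these differences.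

The compounds shown leave open whether the methyl or the aromatic ring matters more in compound 2. A 1,3,4-thiadiazol-2-yl group without the methyl, or a 5-ethyl-1,3,4-thiadiazol-2-yl group, would help separate the two.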